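Shortening the alkoxy chain on a cinnamoyl triketone core

The compounds below may be only part of what the source reports. "The series", "measured", "known", "first", "only" and "open" are said of these compounds alone.

Compound 1 `CCCOC1=C(CCC)C(=O)/C(=C(O)/C=C/c2ccccc2)C(=O)C1(CCC)CCC`: 2.6 uM
Compound 2 `CCCCC1=C(OC)C(CCCC)(CCCC)C(=O)/C(=C(O)\C=C\c2ccccc2)C1=O`: 7.8 uM

In a functional assay on HCT-8 cells (Homo sapiens) for antiproliferative activity, read by sulforhodamine B assay, with a stated time of 3 days (a lower number here means that less compound is needed, a higher number that more compound is needed for the effect), compound 1 gives 2.6 uM, the lower of the two numbers; compound 2 gives 7.8 uM, a gap beyond the scatter. Compound 3 `CCCC1=C(OC)C(CCC)(CCC)C(=O)/C(=C(O)\C=C\c2ccccc2)C1=O` is not yet measured. It differs from compound 1 by hydrogen in place of ethyl on a saturated chain carbon bound to an oxygen on an unsaturated carbon. Within the data shown here, no step between measured compounds matches this change, so the expectation leans on the measured pair. The step from compound 1 to compound 3 is expected to be small, toward a somewhat higher number, with a 1.5-fold higher number from compound 1 to compound 3 (0.19 log units; within the scatter). Compound 3 is estimated at 4 uM, within 1.5 uM to 10 uM.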

Compound 3, concentration for half-maximal effect: 3.5 uM
For compound 3 the middle estimate is 1.1-fold (0.06 log units) above the measured one; the measured number falls inside the stated range.
By their numbers in this assay, from the lowest: compounds 1 and 3 (each within the scatter of the next); then compound 2.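

Replacing propoxy with methoxy on the shared core gives a 1.3-fold higher number from compound 1 to compound 3 (0.13 log units; within the scatter) in this assay. Among these compounds, this is the only step that can be read at this position, and it shows that the shorter chain leaves the number within the scatter. No measurement at hand accounts for this outcome.

The compounds shown leave open how a longer chain, such as hexyloxy, would behave at this position. They also leave open what an amine or a carboxylic acid at the end of the chain would do.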